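Hydroxy to chloro on the aryl ring of the thiosemicarbazone

The source may hold more compounds than are shown below. What is called first, only, known or untested is meant among the compounds shown, and "the series" means these compounds.

Compound 1 `CC1=CC[C@H](C(C)(C)NC(=S)N/N=C/c2ccc(O)cc2)CC1` gives > 100000 nM in a functional assay on K562 cells (Homo sapiens) for inhibition, read by sulforhodamine B assay, with a stated time of 48 h (on this read-out lower numbers stand for stronger inhibition of growth and higher numbers for weaker inhibition of growth), a limit of the assay rather than a number.
Compound 2 `CC1=CC[C@H](C(C)(C)NC(=S)N/N=C/c2ccccc2O)CC1` gives 800 nM in this assay.

Compound 2 thus holds the only number shown; the other value sits at a limit (the limit of > 100000 nM in this assay, at which 1 of the 2 values shown sits). Among the measured compounds shown here, the one measured step, an at least 120-fold lower number from compound 1 to compound 2 (2.09 log units; beyond the scatter), is large. Compound 3 `CC1=CC[C@H](C(C)(C)NC(=S)N/N=C/c2ccccc2Cl)CC1` differs from compound 2 by chloro in place of hydroxy on an aromatic carbon. That step moved the hydroxy but kept it, so it bears only indirectly on replacing it. A move to a higher number is expected, a 13-fold higher number from compound 2 to compound 3 (1.10 log units; beyond the scatter). Compound 3 is estimated at 10000 nM, within 1500 nM to 100000 nM.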

Compound 3, concentration for 50% growth inhibition: 5600 nM
Estimate against measurement, compound 3: 1.8-fold (0.25 log units) above; the measured number falls inside the stated range.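

Chloro in place of hydroxy on this aromatic carbon weakens growth inhibition in this assay but does not abolish it, giving a 7.0-fold higher number from compound 2 to compound 3 (0.85 log units; beyond the scatter). The hydroxy is therefore not essential here, and the change from 4-hydroxyphenyl to 2-chlorophenyl still gives an at least 17-fold lower number from compound 1 to compound 3 (1.25 log units; beyond the scatter). The value of compound 1 is a limit, not a number: the limit of > 100000 nM in this assay, at which 1 of the 3 values shown sits.

On these data alone, it remains open whether an amine or a methoxy on this carbon would match or exceed compound 2 in this assay. As far as these compounds go, the effect of chloro on the other carbons of the ring also remains open.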